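Swapping a Furan Arm for a Bromophenyl Sulfur Arm

The source may report more compounds than this note shows. Statements on the series, on what has been measured and on what is new or still open speak of the compounds shown alone.

Compound 1 `OC[C@H]1O[C@@H](n2cnc3c(NCc4ccco4)ncnc32)[C@H](O)[C@@H]1O`: 36300 nM
Compound 2 `Nc1nc(SCc2cccc(Br)c2)c2ncn([C@@H]3O[C@H](CO)[C@@H](O)[C@H]3O)c2n1`: 2880 nM
Compound 3 `Nc1nc(SI)c2ncn([C@@H]3O[C@H](CO)[C@@H](O)[C@H]3O)c2n1`: 81300 nM

In an assay on isolated protein for binding affinity to Equilibrative nucleoside transporter 1 (Homo sapiens) (a higher number here means a weaker inhibitor, a lower number a stronger inhibitor), compound 1 stands second highest of the three numbers; compound 3 gives the nearest number and compound 2 the lowest. Compound 4 `OC[C@H]1O[C@@H](n2cnc3c(CSc4cccc(Br)c4)ncnc32)[C@H](O)[C@@H]1O` differs from compound 1 by ((3-bromophenyl)sulfanyl)methyl in place of ((furan-2-yl)methyl)amino on an aromatic carbon. Going by the values given here, one measured step bears on this change: a 28-fold higher number from compound 2 to compound 3 (1.45 log units; beyond the scatter), which shows what a 3-bromobenzyl on a sulfur contributes on this core against an iodo. Since compound 4 gains a ((3-bromophenyl)sulfanyl)methyl, a downward step beyond the scatter is expected, a 6.1-fold lower number from compound 1 to compound 4 (0.78 log units; beyond the scatter), tempered because compound 4 lacks the amino that compound 2 carries at 2880 nM. Compound 4 is therefore estimated at 6000 nM, with a range from 1200 nM to 30000 nM.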

Compound 4, half-maximal inhibitory concentration: 363 nM
Compound 4: the middle estimate sits 17-fold (1.22 log units) above what was measured; the whole stated range lies above it.
By their numbers in this assay, from the lowest: compound 4; then compound 2; then compound 1; then compound 3.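

In this assay, the step of a 100-fold lower number from compound 1 to compound 4 (2.00 log units; beyond the scatter) shows that this aromatic carbon of the shared core tolerates ((3-bromophenyl)sulfanyl)methyl in place of ((furan-2-yl)methyl)amino, with a large gain even though the entering arm has no hydrogen-bond donors. The earlier step measured a sulfur substituent only against an iodo, on a different core. Nothing measured here explains this gain.

The swap changes the ring and the linking atoms together, so the compounds shown leave open which part carries the step. From the compounds shown here alone, whether chlorine could replace the bromine, or oxygen the sulfur, also stays open.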